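The source may hold more compounds than are shown below. What is called first, only, known or untested is meant among the compounds shown, and "the series" means these compounds.

Compound 1 `O=C1N=C(N2N=C(c3ccccc3)CC2c2ccccc2O)S/C1=C1/C(=O)Nc2ccccc21` is measured in a functional assay on cells (Cancer cell lines, Homo sapiens) for cytotoxicity, read by sulforhodamine B assay, with a stated time of 48 h (on this read-out lower numbers stand for stronger inhibition of growth and higher numbers for weaker inhibition of growth), at 2090 nM, the highest of the two numbers recorded. For the measured compounds named here, its only measured neighbour is compound 2 `O=C1N=C(N2N=C(c3ccccc3)CC2c2ccccc2O)S/C1=C1/C(=O)Nc2ccc(Br)cc21`, which differs from it by a single bromo substituent; in this assay compound 2 gives 260 nM, and the step of an 8.0-fold lower number from compound 1 to compound 2 (0.91 log units; beyond the scatter) shows how far that single change reached.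

Compound 3 `COc1ccc(C2CC(c3ccccc3)=NN2C2=NC(=O)/C(=C3\C(=O)Nc4ccccc43)S2)cc1` has not yet been measured. It differs from compound 1 in one place: 4-methoxyphenyl in place of 2-hydroxyphenyl on a saturated ring carbon. Going by the values given here, no measured step touches this part of the shared core, so the change from compound 1 to compound 2 does not bear on it directly and offers no guide to direction. With nothing pointing either way, the expected result in this assay for compound 3 is a number near that of compound 1, about 2000 nM within 500 nM to 8000 nM, which means an expected step of a 1.0-fold lower number from compound 1 to compound 3 (0.02 log units; within the scatter) that need not exceed the scatter.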

Compound 3, concentration for 50% growth inhibition: 2020 nM
Compound 3: middle estimate off by 1.0-fold (0.00 log units), on the low side; the range from low to high includes it.
By their numbers in this assay, from the lowest: compound 2; then compounds 3 and 1 (each within the scatter of the next).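

In this assay, 4-methoxyphenyl in place of 2-hydroxyphenyl on the saturated ring carbon gives a 1.0-fold lower number from compound 1 to compound 3 (0.01 log units; within the scatter), so this exchange at this position leaves the reading within the scatter. The entering group has 0 hydrogen-bond donors and 8 heavy atoms, while the leaving group has 1 hydrogen-bond donor and 7 heavy atoms, and this difference comes with no step beyond the scatter in this pair. No evidence is available to explain why compound 1 and compound 3 read alike.

Going by these compounds, it remains open whether a group of another kind on this carbon, such as a carboxylic acid or an amine on the phenyl ring, would shift the reading. For the compounds shown here, it is also open whether adding bromo to compound 3 would give a step like the one seen from compound 1 to compound 2.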